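One Rearranged Ring Pair: Compound 4 in Prospect

A few compounds are considered here, and "the series" means these few. Any claim that something is new, unique, unknown or untested is made for them only; others in the source may bear on it.

Compound 3 `Cc1cc(=O)n(-c2ccc(F)c(F)c2)nc1C(=O)Nc1ccc(Oc2ncnc3ccsc23)c(F)c1` is one of three analogues of a shared core that differ only in the aryl group carried on an aromatic nitrogen. In a functional assay on MCF7 cells (Homo sapiens) for cytotoxicity, read by MTT assay, with a stated time of 72 h (a lower number here means a stronger inhibitor, a higher number a weaker inhibitor), compound 3 gives 6900 nM, the second highest of the three numbers. Compound 2 `Cc1ccc(-n2nc(C(=O)Nc3ccc(Oc4ncnc5ccsc45)c(F)c3)c(C)cc2=O)cc1` gives 7250 nM and compound 1 `Cc1cc(=O)n(-c2ccccc2C(F)(F)F)nc1C(=O)Nc1ccc(Oc2ncnc3ccsc23)c(F)c1` gives 6020 nM. All three sit within the scatter of one another: a 1.2-fold higher number from compound 1 to compound 2 (0.08 log units; within the scatter), a 1.1-fold higher number from compound 1 to compound 3 (0.06 log units; within the scatter) and a 1.1-fold lower number from compound 2 to compound 3 (0.02 log units; within the scatter).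

Compound 4 `Cc1cc(=O)n(-c2ccc(F)c(F)c2)nc1C(=O)Nc1ccc(Oc2ncnc3sccc23)c(F)c1` departs from compound 3 in a different part of the molecule: a group of 9 heavy atoms (6 carbon, 2 nitrogen, 1 sulfur; one five-membered aromatic ring with 1 hetero atom, one six-membered aromatic ring with 2 hetero atoms) in place of a group of 9 heavy atoms (6 carbon, 2 nitrogen, 1 sulfur; one five-membered aromatic ring with 1 hetero atom, one six-membered aromatic ring with 2 hetero atoms), on an oxygen on an aromatic ring. The two compounds contain the same atoms, joined differently. Going by the values given here, none of the measured steps concerns this position; each of them concerns the aryl group on the nitrogen, and each stayed within the scatter. Among the compounds with values here, the data therefore give no precedent for the change, only the observation that the series so far is flat.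

On that basis compound 4 is expected to give about 7000 nM, within a range from 2500 nM to 20000 nM. The expected step is a 1.0-fold higher number from compound 3 to compound 4 (0.01 log units; within the scatter), with no change beyond the scatter anticipated.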

Compound 4, half-maximal inhibitory concentration: 20600 nM
The estimate for compound 4 lay 2.9-fold (0.47 log units) below the measured number; measured number outside the range, above it.
By their numbers in this assay, from the lowest: compounds 1, 3 and 2 (each within the scatter of the next); then compound 4.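

In this assay, rearranging the ring pair on the oxygen gives a 3.0-fold higher number from compound 3 to compound 4 (0.48 log units; beyond the scatter), the only step among those shown that lies beyond the scatter. The number in this series therefore responds to how the atoms of this group are joined, even though the atom, ring, donor and acceptor counts of the group stay the same, whereas the aryl changes on the aromatic nitrogen left it within the scatter. No measurement shown bears on why the rearrangement has this effect.

As far as these compounds go, compound 4 alone carries the rearranged ring pair, so it remains open whether the aryl groups on the nitrogen would stay equivalent alongside it. From the compounds shown here alone, how an amine or a simple phenyl ring in place of the ring pair would read in this assay also remains open.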